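The source may report more compounds than this note shows. Statements on the series, on what has been measured and on what is new or still open speak of the compounds shown alone.

The series shares one core, seen bare in compound 1 `CN(C)c1ccc(C2CC(c3ccc(-n4ccnc4)cc3)=NN2)cc1`, where the amine nitrogen in the ring carries only hydrogen. In a functional assay on HCC1806 cells (Homo sapiens) for inhibition, read by sulforhodamine B assay, tested at 10 uM (on this read-out higher numbers stand for more inhibition at the one concentration tested (going by the name of the read-out) and lower numbers for less inhibition), compound 1 gives -20.9%. Compound 2 `CN(C)c1ccc(C2CC(c3ccc(-n4ccnc4)cc3)=NN2C(=O)c2cc(Cl)cc(Cl)c2)cc1` carries a (3,5-dichlorophenyl)carbonyl on that nitrogen, and in this assay compound 2 gives 44.5%, a change of a number 65.4 percentage points higher from compound 1 to compound 2 (beyond the scatter). Compound 3 `CN(C)c1ccc(C2CC(c3ccc(-n4ccnc4)cc3)=NN2S(C)(=O)=O)cc1` carries a methylsulfonyl there instead; in this assay compound 3 gives 11.3%, which puts it second of the three, separated from compound 1 by a number 32.2 percentage points higher from compound 1 to compound 3 (beyond the scatter) and from compound 2 by a number 33.2 percentage points lower from compound 2 to compound 3 (beyond the scatter).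

Compound 4 `Cc1ccc(S(=O)(=O)N2N=C(c3ccc(-n4ccnc4)cc3)CC2c2ccc(N(C)C)cc2)cc1` differs from compound 3 in a single place: 4-methylphenyl in place of methyl on a sulfonyl sulfur. Two measured steps speak to this. The step of a number 32.2 percentage points higher from compound 1 to compound 3 (beyond the scatter) shows that the methylsulfonyl raised the read-out, and the step of a number 33.2 percentage points lower from compound 2 to compound 3 (beyond the scatter) shows that an aromatic carbonyl group on the amine nitrogen in the ring stood higher than the methylsulfonyl. Bringing a six-membered aromatic ring onto the sulfonyl sulfur is therefore expected to move the value upward, although no aryl sulfonyl has been measured and the size is uncertain. Compound 4 is expected to show a step of a number 23.7 percentage points higher from compound 3 to compound 4 (beyond the scatter). For compound 4 the estimate in this assay is 35%, with a range from 10% to 60%.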

Compound 4, a percentage reported as inhibition, at one concentration (the size of the read-out at that concentration, not a potency): 66%
The estimate for compound 4 lay 31 percentage points below the measured number; measured number outside the range, above it.
By their numbers in this assay, from the lowest: compound 1; then compound 3; then compound 2; then compound 4.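

Placing 4-methylphenyl on the sulfonyl sulfur in this assay gives a number 54.7 percentage points higher from compound 3 to compound 4 (beyond the scatter), which shows that the group carried by the sulfur matters greatly, something the methylsulfonyl of compound 3 alone could not reveal. The earlier order of aromatic carbonyl over sulfonyl therefore holds only for the methylsulfonyl, since the (4-methylphenyl)sulfonyl gives a number 21.5 percentage points higher from compound 2 to compound 4 (beyond the scatter), and this modest step, together with a number 86.9 percentage points higher from compound 1 to compound 4 (beyond the scatter), puts compound 4 highest of the four, beyond the scatter of each of the others. Nothing in the available data accounts for this rise.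

On these data alone, it remains open whether the rise comes from the six-membered aromatic ring itself or from its methyl, a question that a plain phenylsulfonyl would address, along with a 4-methoxyphenyl or 4-chlorophenyl group on the sulfur. A 3,5-dichlorophenyl group on the sulfonyl sulfur would also separate the effect of the ring's substituents from that of the sulfonyl in place of the carbonyl, and a benzyl group there would test whether the ring must sit directly on the sulfur.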